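This account rests on a few compounds, and the source may have more. Where it says the series, first, only, none or still open, it means among the compounds named here.

Measured compounds:
compound 1, `O=C1NC(=O)C(Cc2ccc(Oc3ccccc3)cc2)S1`: 307 nM
compound 2, `Cc1ccnc(Oc2ccc(CC3SC(=O)NC3=O)cc2)c1`: 4280 nM

Among the measured compounds shown here, in a functional assay for agonist activity at Free fatty acid receptor 1 (Homo sapiens), read by FLIPR, in the presence of a further agent that is not named here (a lower number here means that less compound is needed, a higher number that more compound is needed for the effect), compound 2 gives the higher of the two numbers; its nearest neighbour is compound 1, and the single measured step, a 14-fold higher number from compound 1 to compound 2 (1.14 log units; beyond the scatter), lies beyond the scatter. Compound 3, `O=C1NC(=O)C(Cc2ccc(Oc3cc(C(F)(F)F)ccn3)cc2)S1`, differs from compound 2 by trifluoromethyl in place of methyl on an aromatic carbon. For the measured compounds named here, no measured step exchanges one substituent on that ring for another: the only step available, from compound 1 to compound 2, replaces the whole ring on the oxygen, so it does not directly bear on this change. With nothing pointing either way, the expected step of a 1.4-fold lower number from compound 2 to compound 3 (0.15 log units; within the scatter) is taken as none beyond the scatter, though with wide uncertainty. Compound 3 is therefore estimated at 3000 nM in this assay, within a range from 700 nM to 13000 nM.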

Compound 3, half-maximal effective concentration: 237 nM
Compound 3: the middle estimate sits 13-fold (1.10 log units) above what was measured; measured number outside the range, below it.
By their numbers in this assay, from the lowest: compounds 3 and 1 (each within the scatter of the next); then compound 2.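

In this assay, trifluoromethyl in place of methyl on the aromatic carbon opposite the ring nitrogen gives an 18-fold lower number from compound 2 to compound 3 (1.26 log units; beyond the scatter), a large change from a single substituent. Among the compounds shown here, the earlier step, a 14-fold higher number from compound 1 to compound 2 (1.14 log units; beyond the scatter), exchanged the whole ring on the oxygen, so it could not show that this one place on the ring, with the ring itself unchanged, can by itself move the number so far. Nothing at hand gives a measured reason for the size of this step.

The compounds shown leave open whether a chlorine atom, a methoxy group or an amine at this same carbon would follow trifluoromethyl or methyl. They also leave open whether the same exchange of methyl for trifluoromethyl would have a similar effect on a phenyl ring on the oxygen.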